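Dropping the Trifluoromethyl: Expected Effect on Growth Inhibition

The compounds below may be only part of what the source reports. "The series", "measured", "known", "first", "only" and "open" are said of these compounds alone.

Compound 1 `COc1cc(-c2nn(-c3cccc(NC(=O)c4cccc(C(F)(F)F)c4)c3)cc2-c2ccncc2)ccc1Cl` was tested in a functional assay on SK-OV-3 cells (Homo sapiens) for inhibition, read by sulforhodamine B assay, with a stated time of 48 h; a higher number here means a weaker inhibitor of growth, a lower number a stronger inhibitor of growth. For compound 1 the result is only a limit of the assay, > 50000 nM, a point made by the limit of > 50000 nM in this assay, at which 1 of the 2 values shown sits. A second compound, compound 2 `O=C(Nc1cccc(-n2cc(-c3ccncc3)c(-c3ccc(Cl)c(O)c3)n2)c1)Nc1cc(C(F)(F)F)cc(C(F)(F)F)c1`, differs from compound 1 in several places at once; in this assay compound 2 gives 3810 nM. Compound 3 `COc1cc(-c2nn(-c3cccc(NC(=O)c4ccccc4)c3)cc2-c2ccncc2)ccc1Cl` has not been measured. It differs from compound 1 by hydrogen in place of trifluoromethyl on an aromatic carbon. Among the compounds with values here, no measured pair shows this change, so compound 3 is expected to stay close to compound 1, the step of a number no higher from compound 1 to compound 3 (the limit leaves the size open) not reaching beyond the scatter. The estimate for compound 3 is 50000 nM, between 15000 nM and 100000 nM.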

Compound 3, concentration for total growth inhibition: > 100000 nM
Compound 3: only a limit was reported (the forecaster's own chance of this, stated with the estimate: 70%); middle value at least 2.0-fold (0.30 log units) from the limit.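

Compound 1 and compound 3 each give only a limit in this assay, so the step between them cannot be read. From the compounds shown here alone, whether swapping trifluoromethyl for hydrogen changes growth inhibition at all remains open.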